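A few compounds are considered here, and "the series" means these few. Any claim that something is new, unique, unknown or untested is made for them only; others in the source may bear on it.

In a functional assay on HL-60 cells (Homo sapiens) for cytotoxicity, read by WST assay, with a stated time of 48 h (on this read-out higher numbers stand for an effect only at larger amounts of compound and lower numbers for an effect already at smaller amounts), compound 1 `COc1ccccc1C[C@H]1COC(=O)[C@@H]1Cc1ccc(Cl)c(Cl)c1` gives 14000 nM, compound 2 `Cc1ccccc1C[C@H]1COC(=O)[C@@H]1Cc1ccc(Cl)c(Cl)c1` gives 22000 nM and compound 3 `O=C1OC[C@H](Cc2ccccc2F)[C@H]1Cc1ccc(Cl)c(Cl)c1` gives 28000 nM. Compound 3 therefore cannot be told apart from the other two, since all three numbers lie within the normal spread of repeat measurements. The next compound, compound 4 `O=C1OC[C@H](Cc2cccc(O)c2)[C@H]1Cc1ccc(Cl)c(Cl)c1`, keeps the shared core and changes one group: 3-hydroxyphenyl in place of 2-fluorophenyl on a saturated chain carbon bound to a saturated ring carbon. In words, this is 3-hydroxyphenyl in place of 2-fluorophenyl on a saturated chain carbon bound to a saturated ring carbon.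

Among the measured compounds shown here, three measured steps bear on this change, each swapping one small group on an aromatic carbon: a 1.6-fold higher number from compound 1 to compound 2 (0.20 log units; within the scatter), a 2.0-fold higher number from compound 1 to compound 3 (0.30 log units; within the scatter) and a 1.3-fold higher number from compound 2 to compound 3 (0.10 log units; within the scatter). For the measured compounds named here, none of the measured compounds carries a 3-hydroxyphenyl, so these steps offer only indirect guidance, and the new group could still behave differently. Even so, the largest of them, a 2.0-fold higher number from compound 1 to compound 3 (0.30 log units; within the scatter), stays within the scatter, so no step beyond the scatter is expected, and the data favour no direction. The estimated step is a 1.4-fold lower number from compound 3 to compound 4 (0.15 log units; within the scatter). For compound 4 the estimated value is 20000 nM, with an expected range from 8000 nM to 50000 nM.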

Compound 4, half-maximal effective concentration: 48000 nM
Compound 4: the middle estimate sits 2.4-fold (0.38 log units) below what was measured; the measured number falls inside the stated range.
By their numbers in this assay, from the lowest: compounds 1, 2, 3 and 4 (each within the scatter of the next, the first and the last beyond it).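

In this assay, replacing 2-fluorophenyl with 3-hydroxyphenyl gives a 1.7-fold higher number from compound 3 to compound 4 (0.23 log units; within the scatter), so this pair alone shows no clear change. Compared with its other two neighbours, however, the swap at this same position gives a 2.2-fold higher number from compound 2 to compound 4 (0.34 log units; beyond the scatter) and a 3.4-fold higher number from compound 1 to compound 4 (0.54 log units; beyond the scatter), the first steps in this small set to pass the scatter, so replacing 2-methylphenyl or 2-methoxyphenyl with 3-hydroxyphenyl does shift the number, if only modestly. Nothing measured alongside these numbers explains the shift.

The 3-hydroxyphenyl differs from the other three aromatic groups both in the kind of group on the ring and in where that group sits, so the compounds shown leave open which of the two matters. They also leave open how this saturated chain carbon would tolerate something of a different kind, such as an amine or a carboxylic acid on the ring, or a longer chain in place of the ring.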